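Dropping a Chloro Group From a Cathepsin S Inhibitor

The source may report more compounds than this note shows. Statements on the series, on what has been measured and on what is new or still open speak of the compounds shown alone.

Compound 1 `CS(=O)(=O)N1CCc2c(c(-c3ccc(C(F)(F)F)cc3)nn2CC(O)CN2CCC(n3c(O)nc4ccccc43)CC2)C1`: 50 nM
Compound 2 `CS(=O)(=O)N1CCc2c(c(-c3ccc(C(F)(F)F)cc3)nn2CCCN2CCC(n3c(O)nc4ccc(Cl)cc43)CC2)C1`: 30 nM

In an assay on isolated protein for inhibition of cathepsin S (Homo sapiens) (on this read-out lower numbers stand for stronger inhibition and higher numbers for weaker inhibition), compound 2 gives 30 nM, the lower of the two numbers, though its gap to compound 1 at 50 nM lies within the usual scatter, so the two cannot be told apart. Compound 3 `CS(=O)(=O)N1CCc2c(c(-c3ccc(C(F)(F)F)cc3)nn2CCCN2CCC(n3c(O)nc4ccccc43)CC2)C1` differs from compound 2 in one place: hydrogen in place of chloro on an aromatic carbon. Among the measured compounds shown here, no measured pair shows this exact change on its own, so the expected step, a 1.7-fold higher number from compound 2 to compound 3 (0.22 log units; within the scatter), is modest and may not exceed the scatter. For compound 3 the estimate is 50 nM, expected to lie between 20 nM and 125 nM.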

Compound 3, half-maximal inhibitory concentration: 50 nM
Beside the measured number, compound 3's estimate shows no gap at the digits printed; measured number inside the range.
By their numbers in this assay, from the lowest: compounds 2, 1 and 3 (each within the scatter of the next).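

In this assay, putting hydrogen in place of chloro on the aromatic carbon gives a 1.7-fold higher number from compound 2 to compound 3 (0.22 log units; within the scatter), so this chloro group is not shown to matter for this read-out. Putting hydrogen in place of hydroxy on the chain carbon gives no change at the digits printed from compound 1 to compound 3 (within the scatter), so the same holds for that hydroxy group. No outside measurement is available to help interpret either step. Still open, as far as these compounds go, is whether a bromo or methoxy group on that aromatic carbon, or an amine on that chain carbon, would shift the number beyond the scatter.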